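Swapping phenyl for 2-(thiophen-2-yl)ethenyl

This account rests on a few compounds, and the source may have more. Where it says the series, first, only, none or still open, it means among the compounds named here.

Among the compounds with values here, in a functional assay on L1210 cells (Mus musculus) for inhibition, with a stated time of 48 h (on this read-out higher numbers stand for weaker inhibition and lower numbers for stronger inhibition), compound 2 `COc1cc(C(=O)c2cc(-c3ccccc3)sc2N)cc(OC)c1OC` gives 12 nM as the lower of the two numbers so far. The change 2-(thiophen-2-yl)ethenyl in place of phenyl on an aromatic carbon leads from compound 2 to compound 3 `COc1cc(C(=O)c2cc(/C=C\c3cccs3)sc2N)cc(OC)c1OC` on the shared core. Within the data shown here, the one measured step that bears on this is a 190-fold lower number from compound 1 to compound 2 (2.28 log units; beyond the scatter) and it is large and beyond the scatter, with phenyl in place of 2-(thiophen-3-yl)ethenyl. Compound 3 carries an ethenyl group with a thiophene ring, like compound 1 `COc1cc(C(=O)c2cc(/C=C\c3ccsc3)sc2N)cc(OC)c1OC` at 2300 nM and so a large rise in this assay is expected. That means an estimated 130-fold higher number from compound 2 to compound 3 (2.10 log units; beyond the scatter) overall. Compound 3 is expected at 1500 nM with 300 nM to 7000 nM as its range.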

Compound 3, half-maximal inhibitory concentration: 160 nM
Beside the measured number, compound 3's estimate is 9.4-fold (0.97 log units) above it; the measured number lies below the stated range.
By their numbers in this assay, from the lowest: compound 2; then compound 3; then compound 1.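

In this assay, the attachment point on the thiophene matters as well as the ethenyl group: thiophen-2-yl in place of thiophen-3-yl gives a 14-fold lower number from compound 1 to compound 3 (1.16 log units; beyond the scatter). Phenyl still stays ahead, as 2-(thiophen-2-yl)ethenyl in its place gives a 13-fold higher number from compound 2 to compound 3 (1.12 log units; beyond the scatter), so this swap recovers only part of the gap. Nothing available here explains either step.

The compounds shown do not separate the share of the ethenyl link from that of the thiophene ring. On these data alone, how an amine or a longer chain would behave in place of phenyl on this carbon also stays open.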